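The source may hold more compounds than are shown below. What is called first, only, known or untested is meant among the compounds shown, and "the series" means these compounds.

Values so far in a functional assay on HCT-116 cells (Homo sapiens) for inhibition, read by sulforhodamine B assay, with a stated time of 48 h, tested at 50 uM (on this read-out higher numbers stand for more inhibition of growth at the one concentration tested and lower numbers for less inhibition of growth), are these.

- compound 1 `COc1ccc([C@@H]2C/C(=N/OCc3cn(-c4ccc(C#N)cc4)nn3)c3cc(CC=C(C)C)c(OC)cc3O2)cc1` gives 50%
- compound 2 `COc1cc2c(cc1CC=C(C)C)C(=O)C[C@@H](c1ccc(Oc3ccc(F)cc3)cc1)O2` gives 29%
- compound 3 `COc1cc2c(cc1CC=C(C)C)C(=O)C[C@@H](c1ccc(Oc3cccc([N+](=O)[O-])c3)cc1)O2` gives 46%

Compound 1 and compound 3 lie within the scatter of each other, while compound 2 lies lower than compound 1, beyond the scatter. Compound 4 `COc1ccc([C@@H]2C/C(=N/OCc3cn(-c4ccc(NC(C)=O)cc4)nn3)c3cc(CC=C(C)C)c(OC)cc3O2)cc1` keeps the core of compound 1 and changes one group (acetamido in place of cyano on an aromatic carbon), with acetamido in place of cyano on an aromatic carbon. For the measured compounds named here, the only measured step, a number 17 percentage points higher from compound 2 to compound 3 (beyond the scatter), involves different groups at another place, so it bears only loosely, showing that one swap can move this assay by that much. No firm direction follows, so the expected change stays within the scatter, an estimated a number 5 percentage points lower from compound 1 to compound 4 (within the scatter) with either sign possible. The estimate for compound 4 is 45%, with an expected range from 29% to 61%.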

Compound 4, percent growth inhibition at one concentration: 6%
Beside the measured number, compound 4's estimate is 39 percentage points above it; the whole stated range lies above it.
By their numbers in this assay, from the lowest: compound 4; then compound 2; then compounds 3 and 1 (each within the scatter of the next).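

For the compounds shown here, this position, para to a large group, turns out to matter strongly in this assay: 4-acetamidophenyl in place of 4-cyanophenyl gives a number 44 percentage points lower from compound 1 to compound 4 (beyond the scatter), a far bigger move than the only earlier step. A change of a single small group on the same core can therefore remove most of the growth inhibition seen at the one concentration tested. No measurement at hand explains this drop.

The compounds shown leave open how other groups would behave at this place. An amine or a carboxylic acid could show whether the result is specific to acetamido.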